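The compounds below may be only part of what the source reports. "The series", "measured", "known", "first", "only" and "open" are said of these compounds alone.

compound 1 `O=C(CN1CCN(C(=O)c2ccccc2)CC1)N1CCN(CCCc2c[nH]c3ccc(F)cc23)CC1`: 148000 nM
compound 2 `O=C(CN1CCN(C(=O)c2ccc(Br)cc2)CC1)N1CCN(CCCc2c[nH]c3ccc(F)cc23)CC1`: 60500 nM
compound 3 `O=C(CN1CCN(C(=O)c2cccc(Cl)c2)CC1)N1CCN(CCCc2c[nH]c3ccc(F)cc23)CC1`: 66200 nM

These three compounds were measured in an ADME assay on HEK293 cells (Homo sapiens) for cytotoxicity, read by MTT assay, with a stated time of 72 h; a lower number here means a stronger inhibitor, a higher number a weaker inhibitor. Compound 3, at 66200 nM, lies well under compound 1 but level with compound 2, as a 2.2-fold lower number from compound 1 to compound 3 (0.35 log units; beyond the scatter) and a 1.1-fold higher number from compound 2 to compound 3 (0.04 log units; within the scatter) show.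

The next compound is compound 4 `O=C(CN1CCN(C(=O)c2cccc(Br)c2)CC1)N1CCN(CCCc2c[nH]c3ccc(F)cc23)CC1`, which has bromo in place of chloro on an aromatic carbon, meta to a large group (bromo in place of chloro on an aromatic carbon).

Among the measured compounds shown here, no measured step makes exactly this swap, so the evidence is indirect. Adding a halogen to the bare ring gave a 2.4-fold lower number from compound 1 to compound 2 (0.39 log units; beyond the scatter) with bromo, a modest step close in size to the chloro step above. The 3-chlorophenyl of compound 3 and the 4-bromophenyl of compound 2 also differ in both halogen and position, yet their step stays within the scatter. Neither comparison points to a real change in this assay, so none beyond the scatter is expected.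

The estimated change is a 1.1-fold lower number from compound 3 to compound 4 (0.03 log units; within the scatter). For compound 4 the estimate is 62000 nM, with an expected range from 36000 nM to 105000 nM.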

Compound 4, half-maximal inhibitory concentration: 40600 nM
Estimate against measurement, compound 4: 1.5-fold (0.18 log units) above; the measured number falls inside the stated range.
By their numbers in this assay, from the lowest: compounds 4, 2 and 3 (each within the scatter of the next); then compound 1.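

In this assay, a 1.6-fold lower number from compound 3 to compound 4 (0.21 log units; within the scatter) means that chloro and bromo cannot be told apart at this position, meta to a large group, and a 1.5-fold lower number from compound 2 to compound 4 (0.17 log units; within the scatter) shows that the 3-bromophenyl and 4-bromophenyl groups cannot be told apart either. Bromo at this position still gives a 3.6-fold lower number from compound 1 to compound 4 (0.56 log units; beyond the scatter), so all three halogen-bearing compounds, with no exception among those shown, now stand beyond the scatter from the unsubstituted compound 1, and the presence of a halogen, rather than which one or where, is what separates them. Nothing measured here explains this result.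

Going by these compounds, it remains open whether fluoro or iodo at this position would fit the same picture. On these data alone, it is equally open whether a group that is not a halogen, such as methyl, methoxy or an amine, would give a similar step from compound 1.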